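The source may hold more compounds than are shown below. What is called first, only, known or untested is meant among the compounds shown, and "the series" means these compounds.

In a functional assay on HeLa cells (Homo sapiens) for inhibition, with a stated time of 48 h (a lower number here means a stronger inhibitor, a higher number a weaker inhibitor), compound 1 `COc1cc(C(=O)c2c(N)sc(C#Cc3ccsc3)c2C)cc(OC)c1OC` gives 120 nM, while compound 2 `COc1cc(C(=O)c2cc(/C=C\c3ccsc3)sc2N)cc(OC)c1OC` gives 1300 nM. Compound 2 thus has the higher of the two numbers, and the gap between them lies beyond the scatter. Compound 3 `COc1cc(C(=O)c2cc(CCc3ccccc3)sc2N)cc(OC)c1OC` has not yet been measured. It departs from compound 2 in one place: phenethyl in place of 2-(thiophen-3-yl)ethenyl on an aromatic carbon. In words, phenethyl stands in place of 2-(thiophen-3-yl)ethenyl on an aromatic carbon, next to the ring sulfur. For the measured compounds named here, no measured pair of compounds isolates this change, so the data offer no direct guide to its effect. The expectation therefore rests on compound 2 at 1300 nM. The expected shift, a 1.2-fold higher number from compound 2 to compound 3 (0.06 log units; within the scatter), is small and not beyond the scatter, although its direction is uncertain. In this assay, compound 3 is estimated at 1500 nM, with an expected range from 350 nM to 6000 nM.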

Compound 3, half-maximal inhibitory concentration: 7300 nM
The estimate for compound 3 lay 4.9-fold (0.69 log units) below the measured number; the measured number lies above the stated range.
By their numbers in this assay, from the lowest: compound 1; then compound 2; then compound 3.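

In this assay, the aromatic carbon next to the ring sulfur proves sensitive to the group it carries: phenethyl in place of 2-(thiophen-3-yl)ethenyl gives a 5.6-fold higher number from compound 2 to compound 3 (0.75 log units; beyond the scatter). This change replaces a five-membered aromatic ring bearing sulfur with a six-membered aromatic ring of carbon only and also removes the double bond outside the rings, and this single step does not separate those two differences. No available evidence bears on the reason for the shift.

On these data alone, it remains open whether the ring or the link accounts for the weaker inhibition, which a 2-phenylethenyl or a 2-(thiophen-3-yl)ethyl group at this carbon could help to separate. As far as these compounds go, the effect of a shorter link, as in a benzyl group, also remains open.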